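Cytotoxicity notes: isopropylthiazole to trifluoromethylpyrazole exchange

This account rests on a few compounds, and the source may have more. Where it says the series, first, only, none or still open, it means among the compounds named here.

Measured so far:
- compound 1 `COc1ccc2c(O[C@H]3C[C@H]4C(=O)N(C)CCCC/C=C/[C@@H]5C[C@@]5(C(=O)NS(=O)(=O)C5(C)CC5)NC(=O)N4C3)cc(-c3nc(C(C)C)cs3)nc2c1Cl` gives 48500 nM in an ADME assay on Huh-7 cells (Homo sapiens) for cytotoxicity, read by colorimetric assay; a lower number here means that less compound is tolerated, a higher number that more compound is tolerated
- compound 2 `COc1ccc2c(O[C@H]3C[C@H]4C(=O)N(C)CCCC/C=C/[C@@H]5C[C@@]5(C(=O)NS(=O)(=O)C5(C)CC5)NC(=O)N4C3)cc(-c3csc(C(C)C)n3)nc2c1Cl` gives 30200 nM in this assay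

For the measured compounds named here, compound 2 holds the lower of the two numbers, but the only measured step, a 1.6-fold lower number from compound 1 to compound 2 (0.21 log units; within the scatter), lies within the scatter, so compounds 1 and 2 are not separated in this assay and no order between them is claimed.

The next compound, compound 3 `COc1ccc2c(O[C@H]3C[C@H]4C(=O)N(C)CCCC/C=C/[C@@H]5C[C@@]5(C(=O)NS(=O)(=O)C5(C)CC5)NC(=O)N4C3)cc(-n3cc(C(F)(F)F)cn3)nc2c1Cl`, carries the change (4-(trifluoromethyl)-1H-pyrazol-1-yl in place of 2-isopropyl-1,3-thiazol-4-yl on an aromatic carbon). Going by the values given here, the one measured step exchanges the attachment of the isopropyl-thiazole on the same aromatic carbon and was within the scatter; it does not test the entry of a trifluoromethyl-pyrazole, so no measured step bears directly on this change. With nothing in the numbers pointing either way, the expectation is a step from compound 2 to compound 3 of a 1.2-fold higher number from compound 2 to compound 3 (0.06 log units; within the scatter), that is, none beyond the scatter. As far as these compounds go, compound 3 is therefore estimated at 35000 nM in this assay, with a range from 14000 nM to 85000 nM, the width reflecting that the change itself is untested.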

Compound 3, half-maximal cytotoxic concentration: 21900 nM
Beside the measured number, compound 3's estimate is 1.6-fold (0.20 log units) above it; the range from low to high includes it.
By their numbers in this assay, from the lowest: compounds 3, 2 and 1 (each within the scatter of the next, the first and the last beyond it).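

In this assay, placing 4-(trifluoromethyl)-1H-pyrazol-1-yl instead of 2-isopropyl-1,3-thiazol-4-yl on this aromatic carbon, next to the ring nitrogen, gives a 1.4-fold lower number from compound 2 to compound 3 (0.14 log units; within the scatter), so compounds 2 and 3 are not separated. Against the other thiazole, 4-isopropyl-1,3-thiazol-2-yl, the same pyrazole gives a 2.2-fold lower number from compound 1 to compound 3 (0.35 log units; beyond the scatter), the only step among these compounds beyond the scatter, and a modest one; because compound 2 lies within the scatter of both compound 1 and compound 3, this one step does not set the two thiazoles apart from the pyrazole as classes. No supporting measurement bears on the reason for this step.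

Each exchange shown changes the ring and its substituent together, so the compounds shown leave open whether the step from compound 1 to compound 3 follows the pyrazole, the trifluoromethyl group or the loss of the isopropyl group. Also open, as far as these compounds go, is how this assay would read with a group other than a substituted five-membered aromatic ring at this position, such as an amine, a carboxylic acid or a phenyl ring.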